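Piperidin-4-yl Replacing 2-(1H-imidazol-4-yl)ethyl on a Shared Core

This account rests on a few compounds, and the source may have more. Where it says the series, first, only, none or still open, it means among the compounds named here.

Four compounds share a core on which three groups sit. Compound 1 `c1ccc(Cn2c(CCc3c[nH]cn3)nnc2Cc2c[nH]c3ccccc23)cc1` carries a benzyl group and a 2-(1H-imidazol-4-yl)ethyl chain; in an assay on cells for displacement of a labelled ligand from somatostatin receptor type 4 (Homo sapiens), with a stated time of 90 min (a lower number here means a stronger inhibitor, a higher number a weaker inhibitor), compound 1 reaches only a limit of the assay, > 10000 nM. Compound 2 `c1ccc(Cn2c(Cc3c[nH]c4ccccc34)nnc2C2CCNCC2)cc1` has piperidin-4-yl in place of that chain (piperidin-4-yl in place of 2-(1H-imidazol-4-yl)ethyl on an aromatic carbon); in this assay compound 2 likewise gives only a limit, > 10000 nM. The step that the two limits leave unreadable from compound 1 to compound 2 cannot be sized because of the limit of > 10000 nM in this assay, at which 2 of the 3 values shown sit. Compound 3 `Clc1ccc(Cn2c(CCc3c[nH]cn3)nnc2CCc2c[nH]c3ccccc23)cc1Cl` carries a 3,4-dichlorobenzyl group instead, and how its core differs from that of compound 1 is not broken down here. In this assay, within the data shown here, compound 3 gives 1430 nM, the only number among the measured three. Compound 4 `Clc1ccc(Cn2c(CCc3c[nH]c4ccccc34)nnc2C2CCNCC2)cc1Cl` makes the same kind of change from compound 3 (piperidin-4-yl in place of 2-(1H-imidazol-4-yl)ethyl on an aromatic carbon), the new group now sitting next to the ring atom that bears a 3,4-dichlorobenzyl group rather than a benzyl group. With the earlier step unreadable, the expectation rests on compound 3 and its value 1430 nM alone. The step of a 1.4-fold higher number from compound 3 to compound 4 (0.15 log units; within the scatter) is expected to be small. Compound 4 is estimated at 2000 nM, between 500 nM and 10000 nM.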

Compound 4, inhibition constant: > 10000 nM
Compound 4: only a limit was reported; the forecaster's own chance of this, stated with the estimate: 25%; middle value at least 5.0-fold (0.69 log units) from the limit.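

In this assay, putting piperidin-4-yl in place of 2-(1H-imidazol-4-yl)ethyl on the core of compound 3 gives an at least 6.9-fold higher number from compound 3 to compound 4 (0.84 log units; beyond the scatter), so on this core the change clearly weakens binding. Compound 4 gives only a limit of the assay, > 10000 nM, so the step has a lower bound but no exact size. The same change on the core of compound 1 cannot be read, so the series does not show whether the loss carries from one core to another, because both ends of that step are limits and only compound 3 gives a true number: the limit of > 10000 nM in this assay, at which 3 of the 4 values shown sit.

The compounds shown leave open how an open-chain amine such as 2-aminoethyl, or a carboxylic acid, would fare in that place on the core of compound 3. They also leave open how much of the number for compound 3 belongs to its 3,4-dichlorobenzyl group, as against a benzyl group on an otherwise identical core.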